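The source may report more compounds than this note shows. Statements on the series, on what has been measured and on what is new or still open speak of the compounds shown alone.

Compound 1 `CN(C)CCCCCSC1=Nc2ccccc2C(CC(=O)NCc2ccccc2)N1c1ccc(-c2ccc(F)cc2)cc1` — 97.6%
Compound 2 `O=C(CC1c2ccccc2N=C(SCCCCCN2CCCC2)N1c1ccc(-c2ccccc2)cc1)NCc1ccc(F)cc1` — 51.5%

In an assay on cells for inhibition of Voltage-dependent T-type calcium channel subunit alpha-1G (Homo sapiens), read by patch clamp, tested at 10 uM (on this read-out lower numbers stand for less inhibition and higher numbers for more inhibition at the one concentration tested (going by the name of the read-out)), compound 1 gives 97.6%, the higher of the two numbers, while compound 2 gives 51.5%, a gap beyond the scatter. The two structures differ in several places, so no single change can be tied to that gap. Compound 3 `CN(C)CCCCCSC1=Nc2ccccc2C(CC(=O)NCc2ccccc2)N1c1ccc(-c2ccccc2)cc1` differs from compound 1 in one place: hydrogen in place of fluoro on an aromatic carbon. For the measured compounds named here, no measured pair isolates this change. Compound 1 stands close to the top of the read-out with 97.6%, so a modest loss rather than a gain is expected. Compound 3 is expected to give 88% in this assay, within 70% to 99%, a step of a number 9.6 percentage points lower from compound 1 to compound 3 (within the scatter).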

Compound 3, a percentage reported as inhibition, at one concentration (the size of the read-out at that concentration, not a potency): 76.2%
Estimate against measurement, compound 3: 11.8 percentage points above; the measured number falls inside the stated range.
By their numbers in this assay, from the lowest: compound 2; then compound 3; then compound 1.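

In this assay, for the compounds shown here, 4-fluorophenyl to phenyl gives the first one-place step, a number 21.4 percentage points lower from compound 1 to compound 3 (beyond the scatter), so the fluoro on this aromatic carbon matters to the read-out with the rest of compound 1 held fixed. The size of that step shows that this position is not neutral to the change, even with compound 1 close to the top of the read-out. Nothing at hand gives a reason for the step.

From the compounds shown here alone, whether chloro or a methoxy group at this place would match fluoro remains open. Also open, going by these compounds, is whether the step would hold with a pyrrolidine in place of the dimethylamine at the chain end.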